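Swapping Hydroxy for Nitro on a Second Core

The source may report more compounds than this note shows. Statements on the series, on what has been measured and on what is new or still open speak of the compounds shown alone.

Compound 1, `Oc1ccc(-c2nc3cc(C(F)(F)F)ccc3[nH]2)cc1`: 51000 nM
Compound 2, `Oc1ccc(-c2nc3cc(Cl)c(Cl)cc3[nH]2)cc1`: 11000 nM
Compound 3, `O=[N+]([O-])c1ccc(-c2nc3cc(C(F)(F)F)ccc3[nH]2)cc1`: 6000 nM

These three were measured in an ADME assay on MDBK cells (Bos taurus) for cytotoxicity, read by MTT assay, with a stated time of 96 h; on this read-out higher numbers stand for lower toxicity in this test and lower numbers for higher toxicity in this test. Compound 1 and compound 3 share a core and differ in one place, (nitro in place of hydroxy on an aromatic carbon); that change produced an 8.5-fold lower number from compound 1 to compound 3 (0.93 log units; beyond the scatter). The cores of compound 1 and compound 2 differ as well, but the difference between the two cores is not broken down here. Compound 4, `O=[N+]([O-])c1ccc(-c2nc3cc(Cl)c(Cl)cc3[nH]2)cc1`, is not yet measured and differs from compound 2 by the same change, (nitro in place of hydroxy on an aromatic carbon). A step of similar direction is expected from compound 2 to compound 4 in this assay, though somewhat smaller than the earlier one, because compound 2 already gives 11000 nM while compound 3 gives 6000 nM. Compound 4 is therefore expected to give about 2000 nM, between 700 nM and 6000 nM, which amounts to an expected 5.5-fold lower number from compound 2 to compound 4 (0.74 log units; beyond the scatter).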

Compound 4, half-maximal cytotoxic concentration: 56000 nM
For compound 4 the middle estimate is 28-fold (1.45 log units) below the measured one; measured number above the stated range.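

In this assay the same swap of hydroxy for nitro gave a 5.1-fold higher number from compound 2 to compound 4 (0.71 log units; beyond the scatter), the reverse of the direction seen on the other core. The change therefore does not carry its effect on this number from one core to the other in this series, and the two steps differ by more than the scatter: the same change on two cores in this assay, an 8.5-fold lower number (0.93 log units; beyond the scatter) from compound 1 to compound 3 and a 5.1-fold higher number (0.71 log units; beyond the scatter) from compound 2 to compound 4, 43-fold (1.64 log units) apart, beyond the scatter of two such steps

Going by these compounds alone, this does not show why the steps part: each core offers only one pair, and the difference between the cores is not broken down. The compounds shown leave open how an amine or a carboxylic acid in place of the hydroxy would behave on either core. They also leave open which core's behaviour a core carrying a single chlorine would follow.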